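The source may hold more compounds than are shown below. What is called first, only, known or untested is meant among the compounds shown, and "the series" means these compounds.

Working notes on the series. In a functional assay on A549 cells (Homo sapiens) for antiproliferative activity, read by MTT assay, with a stated time of 48 h (on this read-out lower numbers stand for stronger inhibition and higher numbers for weaker inhibition), compound 1 `CCn1cc(-c2ccc(Cl)cc2)c(=O)c2cc(F)c(N3CCNCC3)cc21` gives 1250 nM. Compound 2 `CCn1cc(-c2ccc(C#N)cc2)c(=O)c2cc(F)c(N3CCNCC3)cc21` gives 1090 nM, within the scatter of compound 1. Compound 3 `CCn1cc(-c2cccc(F)c2)c(=O)c2cc(F)c(N3CCNCC3)cc21` gives 3060 nM, the highest number of the three.

Compound 4 `O=c1c(-c2ccc(Cl)cc2)cn(C2CC2)c2cc(N3CCNCC3)c(F)cc12` keeps the 4-chlorophenyl group of compound 1 and has cyclopropyl in place of ethyl on an aromatic nitrogen.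

For the measured compounds named here, no measured step touches this nitrogen substituent, so the data give no direct measure of the change. All three steps concern the aromatic substituent, and they are small to modest: a 1.1-fold lower number from compound 1 to compound 2 (0.06 log units; within the scatter), a 2.4-fold higher number from compound 1 to compound 3 (0.39 log units; beyond the scatter) and a 2.8-fold higher number from compound 2 to compound 3 (0.45 log units; beyond the scatter). They show only how far the numbers have moved so far within this series.

With nothing pointing either way, no change beyond the scatter is expected in this assay, and the anchor remains compound 1 at 1250 nM. The expected step is a 1.1-fold lower number from compound 1 to compound 4 (0.06 log units; within the scatter). The estimated value for compound 4 is 1100 nM. The expected range for compound 4 runs from 450 nM to 2800 nM.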

Compound 4, half-maximal inhibitory concentration: 650 nM
The estimate for compound 4 lay 1.7-fold (0.23 log units) above the measured number, within the range that was stated.
By their numbers in this assay, from the lowest: compounds 4, 2 and 1 (each within the scatter of the next); then compound 3.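

In this assay, the substituent on the aromatic nitrogen now has its first reading: with the 4-chlorophenyl group kept, cyclopropyl in place of ethyl gives a 1.9-fold lower number from compound 1 to compound 4 (0.28 log units; within the scatter). At this position, then, a three-membered non-aromatic ring of carbon only can stand in place of the ethyl chain with the two numbers remaining within the scatter of each other, at least for this single pair. No measurement at hand bears on what lies behind the size of this step.

On these data alone, this is one pair, so it remains open whether the same change would give a similar step alongside the 4-cyanophenyl or 3-fluorophenyl group. Also open, as far as these compounds go, is how the number responds on this nitrogen to a longer chain such as propyl, to a benzyl group, or to a 2-hydroxyethyl chain.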